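The source may hold more compounds than are shown below. What is called first, only, known or untested is meant among the compounds shown, and "the series" means these compounds.

Compound 3 `C=COc1ccccc1OC(C)C1=NCCN1` gives 3160 nM in a functional assay on CHO cells for agonist activity at Alpha-2B adrenergic receptor (Homo sapiens) (a lower number here means that less compound is needed, a higher number that more compound is needed for the effect), the highest of the three numbers recorded. Its nearest neighbour is compound 2 `CC(C)Oc1ccccc1OC(C)C1=NCCN1`, which gives 1740 nM; the step of a 1.8-fold higher number from compound 2 to compound 3 (0.26 log units; within the scatter) stays within the scatter. Furthest away is compound 1 `CC(Oc1ccccc1Br)C1=NCCN1`, which gives 316 nM in this assay, and the steps of a 5.5-fold higher number from compound 1 to compound 2 (0.74 log units; beyond the scatter) and a 10-fold higher number from compound 1 to compound 3 (1.00 log units; beyond the scatter) both lie beyond the scatter.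

Compound 4 `COc1ccccc1OC(C)C1=NCCN1` differs from compound 3 only in methyl in place of vinyl on an oxygen on an aromatic ring. Going by the values given here, the step that bears on it is the one between compound 2 and compound 3, where one group on that oxygen gave way to another with no change beyond the scatter. A second swap of the group on the same oxygen is therefore expected to leave this assay about where compound 3 stands, with a step of a 1.3-fold lower number from compound 3 to compound 4 (0.10 log units; within the scatter) that is not expected to exceed the scatter. Compound 4 is accordingly estimated at 2500 nM in this assay, within a range from 1000 nM to 6300 nM.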

Compound 4, half-maximal effective concentration: 100000 nM
Beside the measured number, compound 4's estimate is 40-fold (1.60 log units) below it, outside the stated range (above it).
By their numbers in this assay, from the lowest: compound 1; then compounds 2 and 3 (each within the scatter of the next); then compound 4.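

Going by these compounds alone, the group on the oxygen on an aromatic ring matters far more in this assay than the earlier compounds suggested: methyl in place of vinyl gives a 32-fold higher number from compound 3 to compound 4 (1.50 log units; beyond the scatter) and methyl in place of isopropyl gives a 57-fold higher number from compound 2 to compound 4 (1.76 log units; beyond the scatter) even though vinyl and isopropyl themselves stay within the scatter of each other. Exchanging the bromo group for a methoxy group gives a 320-fold higher number from compound 1 to compound 4 (2.50 log units; beyond the scatter) and is the widest step among these four compounds. Nothing available explains why methyl stands so far apart from vinyl and isopropyl.

On these data alone, it remains open whether an ethyl group or a longer chain on that oxygen would follow methyl or stay with vinyl and isopropyl. The compounds shown also leave open how a free hydroxyl group at the same place would compare.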